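Swapping a Butyl for an Oxirane on the Benzylic Carbon

A few compounds are considered here, and "the series" means these few. Any claim that something is new, unique, unknown or untested is made for them only; others in the source may bear on it.

Measured so far:
- compound 1, `CC(=O)c1cc(C)c(OCCCCC#N)cc1O`: 35%
- compound 2, `CCCCCc1cc(C(C)=O)c(O)cc1OCCCCC#N`: 14%

In an assay on isolated protein for binding affinity to leukotriene B4 receptor 1 (Homo sapiens), tested at 1 uM (on this read-out higher numbers stand for more inhibition at the one concentration tested (going by the name of the read-out) and lower numbers for less inhibition), compound 1 gives 35%, while compound 2 gives 14%, the lower of the two numbers. Within the data shown here, the only measured step, a number 21 percentage points lower from compound 1 to compound 2 (beyond the scatter), shows that adding a butyl group on the saturated chain carbon bound to an aromatic carbon costs inhibition. Compound 3, `CC(=O)c1cc(CC2CO2)c(OCCCCC#N)cc1O`, departs from compound 2 by oxiran-2-yl in place of butyl on a saturated chain carbon bound to an aromatic carbon. Among the measured compounds shown here, no measured pair involves an oxirane, so the step from compound 1 to compound 2 is the only guide, and it bears only indirectly: it tells what the butyl group does, not what its replacement will do. From the compounds shown here alone, because compound 2 lost ground with a number 21 percentage points lower from compound 1 to compound 2 (beyond the scatter), some recovery is expected when the butyl leaves, but the oxiran-2-yl is untested, so the expected step is a number 11 percentage points higher from compound 2 to compound 3 (beyond the scatter), with compound 3 estimated at 25%, between 5% and 50%.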

Compound 3, a percentage reported as inhibition, at one concentration (the size of the read-out at that concentration, not a potency): 24%
Estimate against measurement, compound 3: 1 percentage points above; the range from low to high includes it.
By their numbers in this assay, from the lowest: compounds 2 and 3 (each within the scatter of the next); then compound 1.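

Replacing butyl with oxiran-2-yl on this saturated chain carbon bound to an aromatic carbon gives a number 10 percentage points higher from compound 2 to compound 3 (within the scatter), so in this assay the all-carbon chain and the oxygen-bearing three-membered ring cannot be told apart. Set against the hydrogen of compound 1, the same group gives a number 11 percentage points lower from compound 1 to compound 3 (beyond the scatter), which means that both groups placed here, butyl and oxiran-2-yl, stand under compound 1 and that the lower inhibition is not confined to butyl. No evidence at hand accounts for either step.

From the compounds shown here alone, what an amine, a carboxylic acid or a simple methyl at this place would give in this assay stays open. Also open, going by these compounds, is whether any group on this carbon can match or pass compound 1, since the two compared so far both fall short of it.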